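The compounds below may be only part of what the source reports. "The series", "measured", "known", "first", "only" and "open" are said of these compounds alone.

This piece follows a short series of amides that share one core and differ only in the group on the carbonyl carbon. Compound 1 `COc1ccc(-c2cnc(NC(=O)C3CCCCC3)n2C)cc1` carries a cyclohexyl there. In a toxicity assay on THP-1 cells (Homo sapiens) for inhibition (on this read-out lower numbers stand for higher toxicity in this test and higher numbers for lower toxicity in this test), compound 1 gives > 100000 nM, which is a limit of the test and not a number. Compound 2 `COc1ccc(-c2cnc(NC(=O)C3CCCC3)n2C)cc1` carries a cyclopentyl instead. In this assay compound 2 gives > 100000 nM, again a limit. Compound 3 `COc1ccc(-c2cnc(NC(=O)c3cnco3)n2C)cc1` carries a 1,3-oxazol-5-yl. In this assay compound 3 gives > 100000 nM, once more only a limit. So compound 3 stands where every measured compound stands: the limit of > 100000 nM in this assay, at which 3 of the 3 values shown sit. The steps between them, a step that the two limits leave unreadable from compound 1 to compound 2, a step that the two limits leave unreadable from compound 1 to compound 3 and a step that the two limits leave unreadable from compound 2 to compound 3, consequently show no readable size.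

Compound 4 `CCC(=O)Nc1ncc(-c2ccc(OC)cc2)n1C` is not yet measured. It differs from compound 3 in one place: ethyl in place of 1,3-oxazol-5-yl on a carbonyl carbon. For the measured compounds named here, no measured step on this carbonyl carbon can be read, since all three compounds sit at the limit, so no direction or size beyond the scatter can be derived from them, and the plain expectation is that compound 4 also remains at the limit. Compound 4 is estimated at 100000 nM in this assay, within 30000 nM to 300000 nM. The step from compound 3 to compound 4 is expected to read a number no higher from compound 3 to compound 4 (the limit leaves the size open), most likely reported again only as a limit.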

Compound 4, half-maximal cytotoxic concentration: > 100000 nM
Compound 4 ended at the assay's limit; the forecaster's own chance of this, stated with the estimate: 80%; the middle value lies on the limit itself.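

The steps from compound 1, compound 2 and compound 3 to compound 4 cannot be read, since all four compounds sit at the same limit: the limit of > 100000 nM in this assay, at which 4 of the 4 values shown sit.

The compounds shown leave open how much cyclohexyl, cyclopentyl, 1,3-oxazol-5-yl and ethyl on the carbonyl carbon differ, and whether any group there would give a true number in this assay.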